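The source may report more compounds than this note shows. Statements on the series, on what has been measured and on what is new or still open speak of the compounds shown alone.

Measured so far in a functional assay on RAW264.7 cells (Mus musculus) for inhibition, read by Griess assay, with stated times of 1 h and 24 h; a higher number here means a weaker inhibitor, a lower number a stronger inhibitor:
compound 1 `CC(C)c1ccc(COc2ccccc2C2CC(=O)c3ccccc3O2)cc1`: 27100 nM
compound 2 `CCCCCOc1ccccc1C1CC(=O)c2ccccc2O1`: 39200 nM
compound 3 `CC(C)=CCOc1ccccc1C1CC(=O)c2ccccc2O1`: 32700 nM

Compound 1 stands at the lowest of the three numbers in this assay, but both compound 2 and compound 3 sit within the scatter of it, so no order among the three can be read. Compound 4 `COCOc1ccccc1C1CC(=O)c2ccccc2O1` differs from compound 1 in methoxy in place of 4-isopropylphenyl on a saturated chain carbon bound to an oxygen on an aromatic ring. Among the compounds with values here, the steps that bear on this change are a 1.4-fold higher number from compound 1 to compound 2 (0.16 log units; within the scatter) and a 1.2-fold higher number from compound 1 to compound 3 (0.08 log units; within the scatter), both altering the same group at the same place and both within the scatter. Neither step reaches a group as short as methoxy, so the evidence is thin, but it points to no step beyond the scatter. Compound 4 is therefore expected to give 35000 nM in this assay, within 15000 nM to 90000 nM, a step of a 1.3-fold higher number from compound 1 to compound 4 (0.11 log units; within the scatter).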

Compound 4, half-maximal inhibitory concentration: 32600 nM
The estimate for compound 4 lay 1.1-fold (0.03 log units) above the measured number, and the stated range covers the measured number.
By their numbers in this assay, from the lowest: compounds 1, 4, 3 and 2 (each within the scatter of the next).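

Replacing the group on a saturated chain carbon bound to an oxygen on an aromatic ring with methoxy gives no step beyond the scatter in this assay (a 1.2-fold higher number from compound 1 to compound 4 (0.08 log units; within the scatter)), (a 1.0-fold lower number from compound 3 to compound 4 (0.00 log units; within the scatter)) and (a 1.2-fold lower number from compound 2 to compound 4 (0.08 log units; within the scatter)). The range of groups tolerated without a readable step therefore extends to methoxy, with no ring, alongside 4-isopropylphenyl, with its six-membered aromatic ring. No measurement is available that accounts for this flat result.

From the compounds shown here alone, whether an amine or a carboxylic acid at this position would move the number beyond the scatter remains open. Going by these compounds, the effect of changes to the shared core also remains open.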